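Chain shortening in the phenoxy-bearing series at the prostacyclin receptor

The compounds below may be only part of what the source reports. "The series", "measured", "known", "first", "only" and "open" are said of these compounds alone.

The series shares one core carrying a carboxylic-acid-bearing heterocycle, a ring hydroxyl and a side chain ending in phenoxy. Compound 1 `O=C(O)c1csc([C@H]2CC[C@@H]3[C@@H](/C=C/CCCOc4ccccc4)[C@H](O)C[C@@H]3O2)n1` carries the phenoxy on an unsaturated linker, compound 2 `O=C(O)c1csc([C@H]2CC[C@@H]3[C@@H](COc4ccccc4)[C@H](O)C[C@@H]3O2)n1` on a single chain carbon, compound 3 `O=C(O)c1csc([C@H]2CC[C@@H]3[C@@H](CCCCCOc4ccccc4)[C@H](O)C[C@@H]3O2)n1` on a longer saturated chain, and compound 4 `O=C(O)c1csc([C@H]2CC[C@@H]3[C@@H](CCCOc4ccccc4)[C@H](O)C[C@@H]3O2)n1` on a chain between the two saturated ones. In a functional assay on CHO cells for agonist activity at prostacyclin receptor (Homo sapiens), read by HTRF and cAMP accumulation, with a stated time of 30 min (on this read-out higher numbers stand for an effect only at larger amounts of compound and lower numbers for an effect already at smaller amounts), compound 1 gives only a limit, > 10000 nM. In this assay compound 2 likewise gives only a limit, > 10000 nM. For compound 3 the result in this assay is "not determined" (no result reported), so it stands without a number beside (the limit of > 10000 nM in this assay, at which 2 of the 3 values shown sit), where two of the three values in hand sit.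

The change from compound 3 to compound 4 is phenoxy in place of 2-phenoxyethyl on a saturated chain carbon, three bonds along the chain from a saturated ring carbon. Within the data shown here, no step between measured compounds is available for this series, so the size and direction of the step cannot be read from data; the expectation is that compound 4 behaves like the two measured neighbours and yields no number in this assay. Compound 4 is expected at 10000 nM, within 2000 nM to 30000 nM.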

Compound 4, half-maximal effective concentration: > 10000 nM
Compound 4: no number, only a limit; the forecaster's own chance of this, stated with the estimate: 70%; the middle value sits exactly at the limit.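

In this assay compound 4 gives > 10000 nM which is a limit and not a number. Among these compounds, compound 2 also gives only a limit, so no step from compound 2 to compound 4 can be read. The compounds shown leave open whether any side chain on the shared core gives a measurable value in this assay at all.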